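Trifluoromethyl for chloro on the urea aryl of compound 1

The compounds below may be only part of what the source reports. "The series", "measured", "known", "first", "only" and "open" are said of these compounds alone.

Measured so far:
- compound 1 `O=C(Nc1cccc(-n2cc(-c3ccncc3)c(-c3ccc(Cl)c(O)c3)n2)c1)Nc1ccc(Cl)c(Cl)c1`: > 32500 nM
- compound 2 `COc1cc(-c2nn(-c3cccc(NC(=O)c4cccc(C(F)(F)F)c4)c3)cc2-c2ccncc2)ccc1Cl`: > 50000 nM

Both values come from a functional assay on A498 cells (Homo sapiens) for inhibition, read by sulforhodamine B assay, with a stated time of 48 h; a higher number here means that more compound is tolerated, a lower number that less compound is tolerated. For compound 1 the result > 32500 nM is a limit of the assay and not a number. For compound 2 the result > 50000 nM is likewise a limit. Compound 1 therefore stands at the limit of > 32500 nM in this assay, at which 1 of the 2 values shown sits, and no difference between compound 1 and compound 2 can be read from these two entries, since neither gives a number.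

Compound 3 `O=C(Nc1cccc(-n2cc(-c3ccncc3)c(-c3ccc(Cl)c(O)c3)n2)c1)Nc1ccc(Cl)c(C(F)(F)F)c1` is not yet measured in this assay. It differs from compound 1 as follows: trifluoromethyl in place of chloro on an aromatic carbon. The place is ortho to a chloro group and meta to a large group, on the six-membered aromatic ring of carbon only.

Within the data shown here, no step between two measured compounds is available to size this change. With compound 1 sitting at a limit in this assay, the step from compound 1 to compound 3 is expected to be none beyond the scatter, a step that the limit leaves unreadable from compound 1 to compound 3, and compound 3 is expected to come out as a limit again. The estimate for compound 3 in this assay is 40000 nM, within 12000 nM to 120000 nM.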

Compound 3, concentration lethal to 50% of the cells: > 32500 nM
Compound 3: no number, only a limit; the forecaster's own chance of this, stated with the estimate: 75%; the middle value is on the limit's open side.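

In this assay compound 1 gives > 32500 nM, a limit and not a number. Compound 3 gives > 32500 nM, again a limit, so no step can be read between compound 1 and compound 3. The compounds shown give no number in this assay, which leaves open what size, if any, the change from chloro to trifluoromethyl has there.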